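A few compounds are considered here, and "the series" means these few. Any claim that something is new, unique, unknown or untested is made for them only; others in the source may bear on it.

Compound 1: `Cc1cccnc1-c1ccc(C(=O)Nc2ccc(Cl)cc2)cc1` gives 1500 nM in a functional assay for antagonist activity at transient receptor potential cation channel subfamily V member 1 (Homo sapiens), read by FLIPR; a lower number here means a stronger inhibitor, a higher number a weaker inhibitor.
Compound 2: `CC(C)(C)c1ccc(NC(=O)c2ccc(-c3ncccc3C#N)cc2)cc1` gives 30 nM in this assay.

Compound 2 stands lowest of the two numbers recorded; the nearest neighbour, compound 1, gives a far higher number, and the gap between the two lies well beyond the usual scatter. The two compounds differ in more than one place, so their values say only what the numbers show.

Compound 3, `CN(C)Cc1cccnc1-c1ccc(C(=O)Nc2ccc(C(C)(C)C)cc2)cc1`, has not yet been measured. Its structure follows from compound 2 by one change: (dimethylamino)methyl in place of cyano on an aromatic carbon. For the measured compounds named here, no measured pair shows this change, so there is no directly comparable step. On the data available, the expected outcome for compound 3 is a moderate move toward a higher number, of a size a 3.3-fold higher number from compound 2 to compound 3 (0.52 log units; beyond the scatter), possibly just beyond the scatter. The estimate for compound 3 is 100 nM, within a range from 30 nM to 400 nM.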

Compound 3, half-maximal inhibitory concentration: 746 nM
Compound 3: middle estimate off by 7.5-fold (0.87 log units), on the low side, and the stated range ends below it.
By their numbers in this assay, from the lowest: compound 2; then compounds 3 and 1 (each within the scatter of the next).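

In this assay, for the compounds shown here, the aromatic carbon ortho to a large group, two atoms from the ring nitrogen, proves sensitive to substitution: (dimethylamino)methyl in place of cyano gives a 25-fold higher number from compound 2 to compound 3 (1.40 log units; beyond the scatter) and this large step is the first reading of this position on its own. Both groups count one hydrogen-bond acceptor and no net charge, so these counts alone do not fix the value at this position. Nothing measured here bears on the reason for a step of this size.

As far as these compounds go, one exchange cannot separate the loss of cyano from the entry of (dimethylamino)methyl, so which of the two drives the step stays open. The compounds shown also leave open how an aminomethyl or a hydroxymethyl group would read on this same carbon.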